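Sulfonamide series: trimming the group on the sulfonyl sulfur

A few compounds are considered here, and "the series" means these few. Any claim that something is new, unique, unknown or untested is made for them only; others in the source may bear on it.

Measured so far:
compound 1 `CN(C)c1ccc(O)c2ccccc12` — in an assay on isolated protein for inhibition of histone acetyltransferase p300 (Homo sapiens), read by fluorescence, with a stated time of 5 min, in the presence of a further agent that is not named here (on this read-out higher numbers stand for weaker inhibition and lower numbers for stronger inhibition), compound 1 gives 3700 nM
compound 2 `NCc1ccc(O)c2ccccc12` — in this assay compound 2 gives "not determined" (no result reported)
compound 3 `Cc1ccc(S(=O)(=O)Nc2ccc(O)c3ccccc23)cc1` — in this assay compound 3 gives 2600 nM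

Compound 3 holds the smaller of the two numbers, but its gap to compound 1 lies within the usual scatter, so the two are not separated; compound 2 contributes no number. Compound 4 `CS(=O)(=O)Nc1ccc(O)c2ccccc12` differs from compound 3 in one place: methyl in place of 4-methylphenyl on a sulfonyl sulfur. For the measured compounds named here, no measured pair shows the effect of such a change, so the step is a guess. A modest step toward a higher number is expected in this assay, namely a 1.7-fold higher number from compound 3 to compound 4 (0.24 log units; within the scatter), though no change beyond the scatter would not surprise. Compound 4 is accordingly expected at 4500 nM, with a range from 1500 nM to 14000 nM.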

Compound 4, half-maximal inhibitory concentration: 3000 nM
Compound 4: middle estimate off by 1.5-fold (0.18 log units), on the high side; the measured number falls inside the stated range.
By their numbers in this assay, from the lowest: compounds 3, 4 and 1 (each within the scatter of the next).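

In this assay this position now has its first direct pair, a 1.2-fold higher number from compound 3 to compound 4 (0.06 log units; within the scatter), so replacing 4-methylphenyl on the sulfonyl sulfur with methyl gives no separable change and the aromatic ring of that group is not shown to matter here. Methanesulfonamido in place of dimethylamino on an aromatic carbon is likewise unresolved, at a 1.2-fold lower number from compound 1 to compound 4 (0.09 log units; within the scatter). Nothing at hand gives a reason for either result.

Open, from the compounds shown here alone, is whether a longer chain such as butyl, or a phenyl ring carrying a carboxylic acid or an amine, on the sulfonyl sulfur would move the number beyond the scatter.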